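Benzoyl in place of a sulfonyl cap on the shared core

The source may report more compounds than this note shows. Statements on the series, on what has been measured and on what is new or still open speak of the compounds shown alone.

Three compounds have so far been measured in a functional assay on A549 cells (Homo sapiens) for antiproliferative activity, read by MTT assay, with a stated time of 48 h; on this read-out higher numbers stand for weaker inhibition and lower numbers for stronger inhibition:
- compound 1 `COc1ccc(-c2cn3cc(C4=CCN(C(=O)c5cccc(C(F)(F)F)c5)CC4)ccc3n2)cc1OC` gives 3690 nM
- compound 2 `COc1ccc(-c2cn3cc(C4=CCN(S(=O)(=O)C5CCCCC5)CC4)ccc3n2)cc1OC` gives 4490 nM
- compound 3 `COc1ccc(-c2cn3cc(C4=CCN(S(=O)(=O)CCc5ccccc5)CC4)ccc3n2)cc1OC` gives 7690 nM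

Compound 3 carries the highest of the three numbers. Its gap to compound 2 is small, a 1.7-fold higher number from compound 2 to compound 3 (0.23 log units; within the scatter), so the two cannot be told apart on this read-out. Its gap to compound 1 is larger, a 2.1-fold higher number from compound 1 to compound 3 (0.32 log units; beyond the scatter), a modest weakening when a sulfonyl cap stands where an aromatic carbonyl cap stood.

Compound 4 `COc1ccc(-c2cn3cc(C4=CCN(C(=O)c5ccccc5)CC4)ccc3n2)cc1OC` differs from compound 3 in one place: benzoyl in place of phenethylsulfonyl on an amine nitrogen in a ring. This step returns the cap to an aromatic carbonyl, so it most nearly undoes the change behind a 2.1-fold higher number from compound 1 to compound 3 (0.32 log units; beyond the scatter), which should run in the opposite direction here; the step of a 1.2-fold higher number from compound 1 to compound 2 (0.09 log units; within the scatter) shows that exchanging one cap for another can also leave the number unchanged. The expected outcome is therefore a modest lowering, a 2.1-fold lower number from compound 3 to compound 4 (0.33 log units; beyond the scatter). Compound 4 is estimated at 3600 nM, with a likely range from 1500 nM to 9000 nM.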

Compound 4, half-maximal inhibitory concentration: 7700 nM
For compound 4 the middle estimate is 2.1-fold (0.33 log units) below the measured one; measured number inside the range.
By their numbers in this assay, from the lowest: compounds 1, 2, 3 and 4 (each within the scatter of the next, the first and the last beyond it).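

In this assay, the benzoyl cap cannot be told apart from the phenethylsulfonyl cap (a 1.0-fold higher number from compound 3 to compound 4 (0.00 log units; within the scatter)) or from the cyclohexylsulfonyl cap (a 1.7-fold higher number from compound 2 to compound 4 (0.23 log units; within the scatter)), so at this ring nitrogen a carbonyl link shows no edge over a sulfonyl link among these compounds. Among the compounds shown here, the only step here beyond the scatter lies on the aromatic ring of the cap: hydrogen in place of trifluoromethyl brings a modest weakening (a 2.1-fold higher number from compound 1 to compound 4 (0.32 log units; beyond the scatter)), so an aromatic carbonyl cap alone does not give the lower number of compound 1. Nothing measured here gives a reason for this step.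

From the compounds shown here alone, it remains open whether this gain is specific to trifluoromethyl or would also appear with a chlorine, a methoxy group or a nitrile on that ring. Also open, going by these compounds, is whether trifluoromethyl would act the same way on a phenylsulfonyl cap.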